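Methoxy to hydroxy on the aryl ring of compound 3

The source may hold more compounds than are shown below. What is called first, only, known or untested is meant among the compounds shown, and "the series" means these compounds.

Measured compounds:
Compound 1 `COc1cc(C)cc(-c2nn(CC#N)cc2-c2ccc(-c3cccc(C(C)=O)c3)nc2)c1` gives 50700 nM.
Compound 2 `Cc1cc(O)cc(-c2nn(CC#N)cc2-c2ccnc(-c3ccc(Oc4ccccc4)cc3)c2)c1` gives 8950 nM.
Compound 3 `COc1cc(C)cc(-c2nn(CC#N)cc2-c2ccnc(-c3ccc(N(C)C)cc3)c2)c1` gives > 10000 nM.

All three were examined in a functional assay on EKVX cells (Homo sapiens) for inhibition, read by sulforhodamine B assay, with a stated time of 48 h; a lower number here means a stronger inhibitor of growth, a higher number a weaker inhibitor of growth. Compound 1 gives 50700 nM there, and compound 2 gives 8950 nM; these two share neither the aryl substituent nor the pyridine substituent, so their values are taken only as they stand. For compound 3 the readout is a limit rather than a number, > 10000 nM. Compound 3 thus stands at the limit of > 10000 nM in this assay, at which 1 of the 3 values shown sits, and its true value is not known beyond that.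

The unmeasured compound 4 `Cc1cc(O)cc(-c2nn(CC#N)cc2-c2ccnc(-c3ccc(N(C)C)cc3)c2)c1` differs from compound 3 in one place: hydrogen in place of methyl on an oxygen on an aromatic ring. Among the compounds with values here, no step between measured compounds carries this change on its own, so any expectation rests on the two values seen for hydroxy and methoxy compounds, which differ in other places as well. The estimate for compound 4 therefore stays close to the limit of compound 3, with wide uncertainty in both directions; the step from compound 3 to compound 4 is expected to be a step that the limit leaves unreadable from compound 3 to compound 4. Compound 4 is expected to give about 15000 nM in this assay, between 4000 nM and 60000 nM.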

Compound 4, concentration for total growth inhibition: 92800 nM
Compound 4: middle estimate off by 6.2-fold (0.79 log units), on the low side, outside the stated range (above it).
By their numbers in this assay, from the lowest: compound 2; then compounds 1 and 4 (each within the scatter of the next).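

In this assay compound 4 gives 92800 nM, which places a number on a compound carrying both the 3-hydroxy-5-methylphenyl group and the dimethylamino group. Within the data shown here, the methoxy to hydroxy change itself cannot be read, because the value for compound 3 is a limit and not a number: the limit of > 10000 nM in this assay, at which 1 of the 4 values shown sits. What compound 4 adds is the first comparison of compounds that differ in one place: with the 3-hydroxy-5-methylphenyl group held constant, dimethylamino in place of phenoxy on an aromatic carbon brings a 10-fold higher number from compound 2 to compound 4 (1.02 log units; beyond the scatter), so in this pair the change of that group carries a large difference in growth inhibition.

As far as these compounds go, whether methoxy and hydroxy differ at all on the aryl ring stays open, as does whether the difference between phenoxy and dimethylamino holds when methoxy replaces hydroxy. Also open, from the compounds shown here alone, is what an amine or a longer alkoxy chain such as ethoxy would give on that ring in place of hydroxy, and what a carboxylic acid would give in place of phenoxy.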